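The source may hold more compounds than are shown below. What is called first, only, known or untested is meant among the compounds shown, and "the series" means these compounds.

Measured so far in a functional assay on HepG2 cells (Homo sapiens) for antiproliferative activity, read by MTT assay, with a stated time of 24 h; a lower number here means a stronger inhibitor, a higher number a weaker inhibitor:
- compound 1 `COc1cc(OC)c(-c2coc3cc(OCc4ccccc4)ccc3c2=O)cc1OC` gives 1320 nM
- compound 2 `COc1cc(OC)c(-c2coc3cc(OCc4ccccc4F)ccc3c2=O)cc1OC` gives 1280 nM

Among the compounds with values here, compound 1 stands level with compound 2, the only other measured compound. Still unmeasured, compound 3 `COc1cc(OC)c(-c2coc3cc(OCc4ccc(F)cc4)ccc3c2=O)cc1OC` differs from compound 1 by fluoro in place of hydrogen on an aromatic carbon (benzyl to 4-fluorobenzyl, para to a large group). Within the data shown here, one measured step bears on this change, also fluoro in place of hydrogen on an aromatic carbon: a 1.0-fold lower number from compound 1 to compound 2 (0.01 log units; within the scatter) (a single step, so thin evidence). No step beyond the scatter is therefore expected in this assay and no direction can be favoured, the estimated step being a 1.1-fold lower number from compound 1 to compound 3 (0.04 log units; within the scatter) (in expectation only). For compound 3 the estimated value is 1200 nM (expected range 600 nM to 2400 nM).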

Compound 3, half-maximal inhibitory concentration: 1000 nM
Compound 3: middle estimate off by 1.2-fold (0.08 log units), on the high side; low and high end bracket the measured number.
By their numbers in this assay, from the lowest: compounds 3, 2 and 1 (each within the scatter of the next).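

In this assay, fluoro on the aromatic carbon para to a large group gives a 1.3-fold lower number from compound 1 to compound 3 (0.12 log units; within the scatter) for benzyl to 4-fluorobenzyl, and moving the fluoro gives a 1.3-fold lower number from compound 2 to compound 3 (0.11 log units; within the scatter) for 2-fluorophenyl to 4-fluorophenyl. Across these three compounds, fluoro is accepted at either of the two carbons without a step beyond the scatter. Nothing on hand accounts for these small steps. Open, as far as these compounds go, is whether a group other than fluoro at the same carbon, such as an amine or a carboxylic acid, would give a step beyond the scatter. Also open, from the compounds shown here alone, is whether a longer chain in place of benzyl would do so.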